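Two Aryl Swaps on a Shared Spiro Core

The source may hold more compounds than are shown below. What is called first, only, known or untested is meant among the compounds shown, and "the series" means these compounds.

Compound 1 `Cc1cccc(-n2nncc2CN2C(=O)C3(C(C#N)=C(N)Oc4c(N)cc5nc6ccccc6nc5c43)c3ccccc32)c1` gives in a functional assay on HepG2 cells (Homo sapiens) for antiproliferative activity, read by MTT assay, with a stated time of 48 h (on this read-out higher numbers stand for weaker inhibition and lower numbers for stronger inhibition), a value of > 50000 nM, which is a limit of this assay and not a number.
Compound 2 `N#CC1=C(N)Oc2c(N)cc3nc4ccccc4nc3c2C12C(=O)N(Cc1cnnn1-c1cccc(C(F)(F)F)c1)c1ccccc12` gives in this assay a value of 15800 nM.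

Among the compounds with values here, compound 2 holds the only real number here; the other value is a limit (the limit of > 50000 nM in this assay, at which 1 of the 2 values shown sits). Within the data shown here, the one measured step, an at least 3.1-fold lower number from compound 1 to compound 2 (0.50 log units; beyond the scatter), changed the group on the same aromatic ring. Compound 3 `CC(=O)Nc1ccc(-n2nncc2CN2C(=O)C3(C(C#N)=C(N)Oc4c(N)cc5nc6ccccc6nc5c43)c3ccccc32)cc1` carries 4-acetamidophenyl in place of 3-(trifluoromethyl)phenyl on an aromatic nitrogen. Without a matching measured step, a shift of similar size in either direction seems possible, so compound 3 is expected near 25000 nM, between 8000 nM and 80000 nM, an estimated 1.6-fold higher number from compound 2 to compound 3 (0.20 log units; within the scatter).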

Compound 3, half-maximal inhibitory concentration: > 50000 nM
Compound 3 gave a limit, no number; the forecaster's own chance of this, stated with the estimate: 35%; at least 2.0-fold (0.30 log units) between middle value and limit.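

The aryl group on the aromatic nitrogen can make the antiproliferative effect weaker as well as stronger: in this assay, 4-acetamidophenyl in place of 3-(trifluoromethyl)phenyl gives an at least 3.1-fold higher number from compound 2 to compound 3 (0.50 log units; beyond the scatter). Among the three aryl groups shown, only 3-(trifluoromethyl)phenyl yields a real number. The step between compound 1 and compound 3 cannot be read, because both values are limits: the limit of > 50000 nM in this assay, at which 2 of the 3 values shown sit.

From the compounds shown here alone, whether compound 1 and compound 3 truly differ remains open. So does the effect of other groups at this nitrogen, such as a phenyl ring carrying an amine or a carboxylic acid.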